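The source may report more compounds than this note shows. Statements on the series, on what has been measured and on what is new or still open speak of the compounds shown alone.

Working notes on the series. In a functional assay on MCF7 cells (Homo sapiens) for inhibition, read by MTT assay, with a stated time of 48 h (on this read-out lower numbers stand for stronger inhibition of growth and higher numbers for weaker inhibition of growth), compound 1 `Cn1cc(C2CC(c3ccccc3)=NN2C(=O)c2ccc(Cl)nc2)c2ccccc21` gives 9250 nM as a measured number. Compound 2 `Cn1cc(C2CC(c3ccccc3)=NN2C(=O)c2cccnc2Cl)c2ccccc21` shows > 10000 nM as a limit of the assay and not a number. Compound 2 therefore stands at the limit of > 10000 nM in this assay, at which 1 of the 2 values shown sits, and has no exact place. Compound 3 `Cn1cc(C2CC(c3ccccc3)=NN2C(=O)c2ccncc2)c2ccccc21` differs from it as follows: pyridin-4-yl in place of 2-chloropyridin-3-yl on a carbonyl carbon with pyridin-4-yl in place of 2-chloropyridin-3-yl on a carbonyl carbon. Only the measured step of an at least 1.0-fold higher number from compound 1 to compound 2 (0.03 log units; that floor lies within the scatter) bears on this change, and its floor lies within the scatter. Within the data shown here, no measured compound carries pyridin-4-yl. The expected step is a number no higher from compound 2 to compound 3 (the limit leaves the size open) and none beyond the scatter is expected. Compound 3 is estimated at 10000 nM and expected to fall between 4000 nM and 20000 nM on this read-out.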

Compound 3, concentration for 50% growth inhibition: 1110 nM
For compound 3 the middle estimate is 9.0-fold (0.95 log units) above the measured one; the whole stated range lies above it.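

The position on the carbonyl carbon does respond to the group it carries in this assay: where moving the chlorine gave no step beyond the scatter, pyridin-4-yl in place of 6-chloropyridin-3-yl gives an 8.3-fold lower number from compound 1 to compound 3 (0.92 log units; beyond the scatter), and pyridin-4-yl in place of 2-chloropyridin-3-yl gives an at least 9.0-fold lower number from compound 2 to compound 3 (0.95 log units; beyond the scatter). Compound 3 is thus the most potent of the three compounds shown. The second step is only a floor, since the value for compound 2 is a limit of the assay and not a number: the limit of > 10000 nM in this assay, at which 1 of the 3 values shown sits.

Both steps remove the chlorine and change the pyridinyl group in a single move, and the compounds shown do not separate these two changes. Going by these compounds, whether a plain phenyl, an unsubstituted pyridin-3-yl or an aminopyridinyl group at this place would match compound 3 remains open.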